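The source may hold more compounds than are shown below. What is called first, only, known or untested is meant among the compounds shown, and "the series" means these compounds.

Compound 1 `COc1cc(C(N)=O)cc2nc(NC(=O)c3ccccn3)n(CCCNC(=O)OCc3ccccc3)c12` in an assay for activation of interferon regulatory factor 3 (Homo sapiens), read by a luciferase reporter, with a stated time of 20 h (a lower number here means that less compound is needed, a higher number that more compound is needed for the effect), gives > 100000 nM, a limit of the assay rather than a number.
Compound 2 `COc1cc(C(N)=O)cc2nc(NC(=O)c3cccnn3)n(CCCNC(=O)OCc3ccccc3)c12` in this assay gives > 100000 nM, also a limit.
Compound 3 `COc1cc(C(N)=O)cc2nc(NC(=O)c3cncn3C)n(CCCNC(=O)OCc3ccccc3)c12` in this assay gives > 100000 nM, again a limit.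

Compound 3 therefore stands at the same limit as the other two measured compounds, the point (the limit of > 100000 nM in this assay, at which 3 of the 3 values shown sit). The piece follows the change from compound 3 to compound 4 `COc1cc(C(N)=O)cc2nc(NC(=O)CCc3ccccc3)n(CCCNC(=O)OCc3ccccc3)c12`: phenethyl in place of 1-methyl-1H-imidazol-5-yl on a carbonyl carbon. The steps measured so far all bear on the carbonyl substituent, but none gives a size: a step that the two limits leave unreadable from compound 1 to compound 2, a step that the two limits leave unreadable from compound 1 to compound 3 and a step that the two limits leave unreadable from compound 2 to compound 3. Three different aromatic groups on that carbonyl carbon all leave the compound at the limit, so the exchange to phenethyl gives no reason to expect a step in this assay that can be read; the estimated step of a number no higher from compound 3 to compound 4 (the limit leaves the size open) is none beyond the scatter. Compound 4 is expected to give about 100000 nM, within the range 30000 nM to 300000 nM, most likely reported once more only as a limit.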

Compound 4, half-maximal effective concentration: > 100000 nM
Compound 4 ended at the assay's limit; the forecaster's own chance of this, stated with the estimate: 80%; the middle value sits exactly at the limit.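

Compound 4, with phenethyl on the carbonyl carbon, gives only a limit, as do compound 1, compound 2 and compound 3, so no step among these four can be read: the limit of > 100000 nM in this assay, at which 4 of the 4 values shown sit.

The compounds shown leave open which group on that carbonyl carbon, if any, would give a readable value in this assay.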